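This account rests on a few compounds, and the source may have more. Where it says the series, first, only, none or still open, it means among the compounds named here.

Of the compounds shown here, three share one core and have been measured, and a fourth awaits its number. Compound 1 `CC(C)=CCC/C(C)=C/CC1Cc2c(OCc3ccccc3)cc(=O)n(CCCO)c2CC1(C)C` gives 1.5% in a functional assay on PANC-1 cells (Homo sapiens) for inhibition, read by MTT assay, with a stated time of 24 h, tested at 10 uM; a lower number here means less inhibition, a higher number more inhibition at the concentration tested (going by the name of the read-out). Compound 2 `CC(C)=CCC/C(C)=C/CC1Cc2c(OCC=C(C)C)cc(=O)n(CCCO)c2CC1(C)C` gives 15.9% in this assay. These two differ at a single place, and the step between them is a number 14.4 percentage points higher from compound 1 to compound 2 (beyond the scatter), a change made on a saturated chain carbon bound to an oxygen on an aromatic ring. Compound 3 `CC(C)=CCC/C(C)=C/CC1Cc2c(OCCCNS(=O)(=O)c3ccc(Br)cc3)cc(=O)n(CCCO)c2CC1(C)C` gives 0% in this assay, the lowest of the three numbers; it and compound 1 lie within the scatter of each other, while compound 2 stands beyond the scatter above compound 3.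

Compound 4 `CC(C)=CCC/C(C)=C/CC1Cc2c(OCCCNC(=O)c3cccs3)cc(=O)n(CCCO)c2CC1(C)C` has not yet been measured. Its difference from compound 3 is (thiophen-2-yl)carbonyl in place of (4-bromophenyl)sulfonyl on an amine nitrogen. Among the compounds with values here, the one measured step, from compound 1 to compound 2, concerns a different part of the molecule, so no measured step bears directly on this change, and the values of compound 1 and compound 3 both sit at the low end of the range seen so far. The step of a number 4 percentage points higher from compound 3 to compound 4 (within the scatter) is therefore expected to stay within the scatter. Compound 4 is expected to give about 4% in this assay, with a likely range from 0% to 16%.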

Compound 4, a percentage reported as inhibition, at one concentration (the size of the read-out at that concentration, not a potency): 11.5%
Beside the measured number, compound 4's estimate is 7.5 percentage points below it; measured number inside the range.
By their numbers in this assay, from the lowest: compounds 3, 1, 4 and 2 (each within the scatter of the next, the first and the last beyond it).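

Within the data shown here, at the amine nitrogen, putting (thiophen-2-yl)carbonyl in place of (4-bromophenyl)sulfonyl gives a number 11.5 percentage points higher from compound 3 to compound 4 (beyond the scatter) in this assay and is the first measured sign that the group on this nitrogen can shift the read-out, though only modestly. The longer chain of compound 4 cannot be told apart from the shorter groups on the same oxygen: a number 4.4 percentage points lower from compound 2 to compound 4 (within the scatter) and a number 10 percentage points higher from compound 1 to compound 4 (within the scatter) both stay within the scatter, even though compound 1 and compound 2 stand apart from each other. No measured evidence is available to explain the change at the nitrogen.

The change swaps the sulfonyl link for a carbonyl and the bromophenyl ring for a thiophene in one move, so the compounds shown cannot say which part accounts for the step. A (4-bromophenyl)carbonyl or a (thiophen-2-yl)sulfonyl group on the same nitrogen would separate the two parts, and a free amine at the end of the chain would show whether any group on this nitrogen is needed at all.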